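The source may hold more compounds than are shown below. What is called first, only, known or untested is meant among the compounds shown, and "the series" means these compounds.

Measured in a functional assay on HCT-116 cells (Homo sapiens) for inhibition, read by sulforhodamine B assay, with a stated time of 48 h, tested at 50 uM; a lower number here means less inhibition of growth, a higher number more inhibition of growth at the concentration tested:
- compound 1 `COc1ccc(/C=C/C(=O)/C=C/c2ccc(OCc3cn(CCOc4cc(=O)oc5ccccc45)nn3)c(OC)c2)cc1OC`: 82%
- compound 2 `COc1cc(/C=C/C(=O)/C=C/c2ccccc2)ccc1OCc1cn(CCOc2cc(=O)oc3ccccc23)nn1`: 56%

Compound 2, at 56%, holds the lower of the two numbers. Compound 3 `COc1ccccc1/C=C/C(=O)/C=C/c1ccc(OCc2cn(CCOc3cc(=O)oc4ccccc34)nn2)c(OC)c1` differs from it by one change, methoxy in place of hydrogen on an aromatic carbon, turning phenyl into 2-methoxyphenyl. Within the data shown here, only one measured step bears on this, a number 26 percentage points lower from compound 1 to compound 2 (beyond the scatter), where phenyl replaced 3,4-dimethoxyphenyl. Read backwards, that step links methoxy groups on this ring with a higher number, but one step is a thin guide. A modest rise is therefore expected, estimated as a number 10 percentage points higher from compound 2 to compound 3 (within the scatter). The expected value for compound 3 is 66%, within an estimated range of 50% to 82%.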

Compound 3, percent growth inhibition at one concentration: 70%
Compound 3: middle estimate off by 4 percentage points, on the low side, and the stated range covers the measured number.
By their numbers in this assay, from the lowest: compound 2; then compound 3; then compound 1.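

Adding one methoxy to the phenyl ring, ortho to a large group, gives a number 14 percentage points higher from compound 2 to compound 3 (beyond the scatter) in this assay, so a single group at this position is enough to move the number beyond the scatter. The 2-methoxyphenyl ring still does not match the 3,4-dimethoxyphenyl ring, with a number 12 percentage points lower from compound 1 to compound 3 (beyond the scatter), so one methoxy here closes only part of the gap between compound 2 and compound 1. Nothing measured here explains these shifts.

Still open, from the compounds shown here alone, is whether a single methoxy elsewhere on this ring would do as well, and whether a hydroxyl, a chlorine or an amine on the same carbon would raise the number as far.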